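Methoxy for fluoro on the benzyl group of compound 2

A few compounds are considered here, and "the series" means these few. Any claim that something is new, unique, unknown or untested is made for them only; others in the source may bear on it.

Measured so far:
compound 1 `COc1ccc(CNc2nc3cc(N)cc(N)c3nc2-c2ccccc2)cc1OC` — 66100 nM
compound 2 `Nc1cc(N)c2nc(-c3ccccc3)c(NCc3ccc(F)cc3)nc2c1` — 5750 nM

Two compounds have been run in a functional assay on NCI/ADR-RES cells (Homo sapiens) for inhibition, read by sulforhodamine B assay, with a stated time of 48 h; on this read-out higher numbers stand for weaker inhibition of growth and lower numbers for stronger inhibition of growth. Among the compounds with values here, compound 2 has the lowest number of the two; its nearest neighbour is compound 1, and the one measured step is an 11-fold lower number from compound 1 to compound 2 (1.06 log units; beyond the scatter), a large one beyond the scatter.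

Compound 3 `COc1ccc(CNc2nc3cc(N)cc(N)c3nc2-c2ccccc2)cc1` is the next member to be measured. The change from compound 2 is methoxy in place of fluoro on an aromatic carbon, on an aromatic carbon of a six-membered aromatic ring of carbon only, para to a large group. Within the data shown here, no measured step covers exactly this exchange; the only step that touches the same benzyl position is the one from compound 1 to compound 2, which swapped a 3,4-dimethoxyphenyl for a 4-fluorophenyl and lowered the number by a large margin. Compound 3 sits structurally between the two, carrying one methoxy where compound 1 carries two and compound 2 carries fluoro. The expectation is therefore a moderate rise in the number from compound 2, a 2.6-fold higher number from compound 2 to compound 3 (0.42 log units; beyond the scatter), without reaching compound 1. Compound 3 is thus estimated at 15000 nM, within a range of 5000 nM to 45000 nM.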

Compound 3, concentration for total growth inhibition: 83200 nM
For compound 3 the middle estimate is 5.5-fold (0.74 log units) below the measured one; the whole stated range lies below it.
By their numbers in this assay, from the lowest: compound 2; then compounds 1 and 3 (each within the scatter of the next).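

In this assay, methoxy in place of fluoro on this aromatic carbon, para to a large group, gives a 14-fold higher number from compound 2 to compound 3 (1.16 log units; beyond the scatter), so this single exchange is a large step on its own and is comparable in size to an 11-fold lower number from compound 1 to compound 2 (1.06 log units; beyond the scatter), the earlier step that changed the whole substitution of the benzyl ring. The additional methoxy of compound 1 has no readable effect in this pair: hydrogen in place of methoxy gives a 1.3-fold higher number from compound 1 to compound 3 (0.10 log units; within the scatter), so compound 1 and compound 3 cannot be told apart, and among these three compounds, only the 4-fluorobenzyl compound, compound 2, stands apart from the others. No measurement bearing on the reason for the step from fluoro to methoxy is available.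

The compounds shown leave open whether fluoro lowers the number or methoxy raises it, a question that a plain benzyl group with hydrogen at this carbon would address. Also open, on these data alone, is how other groups at this carbon, such as chloro, methyl, trifluoromethyl or a dimethylamino group, would compare with fluoro and methoxy.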